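The source may hold more compounds than are shown below. What is called first, only, known or untested is meant among the compounds shown, and "the series" means these compounds.

Compound 2 `Cc1nn(C)cc1Nc1nc(N)c2c(C#N)c(N3CCC[C@H]3C)n(C)c2n1` stands at the upper end of the three numbers available in an assay on isolated protein for inhibition of Leucine-rich repeat serine/threonine-protein kinase 2 (Homo sapiens), read by TR-FRET and LanthaScreen, with stated times of 50 min and 30 min, in the presence of a further agent that is not named here (on this read-out higher numbers stand for weaker inhibition and lower numbers for stronger inhibition), though all three lie within the scatter of one another. In this assay compound 2 gives 38 nM. Compound 3 `C[C@@H]1CCCN1c1c(C#N)c2c(N)nccc2n1C`, which lacks the pyrazole arm altogether, gives 34 nM in this assay, and compound 1 `Cc1c(Nc2nc(N)c3c(C#N)c(N4CCC[C@H]4C)n(C)c3n2)cnn1[C@@H]1CCOC1`, which carries a tetrahydrofuranyl group on the pyrazole nitrogen in place of methyl, gives 20 nM in this assay; neither gap from compound 2 is beyond the scatter.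

Compound 4 `Cc1nn(C2COC2)cc1Nc1nc(N)c2c(C#N)c(N3CCC[C@H]3C)n(C)c2n1` has not been measured. It differs from compound 2 in one place: oxetan-3-yl in place of methyl on an aromatic nitrogen. Within the data shown here, no pair of measured compounds shares exactly this change, so no measured step can be carried over. What the numbers do show is that compound 1, with a larger saturated oxygen ring on that same nitrogen, gives 20 nM against compound 2 at 38 nM, a gap within the scatter.

The step from compound 2 to compound 4 is therefore expected to be small, a 1.4-fold lower number from compound 2 to compound 4 (0.13 log units; within the scatter), with the number for compound 4 estimated at 28 nM, in a range from 10 nM to 80 nM.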

Compound 4, half-maximal inhibitory concentration: 38 nM
Estimate against measurement, compound 4: 1.4-fold (0.13 log units) below; low and high end bracket the measured number.
By their numbers in this assay, from the lowest: compounds 1, 3, 2 and 4 (each within the scatter of the next).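

In this assay there is no change at the digits printed from compound 2 to compound 4 (within the scatter), with oxetan-3-yl in place of methyl on an aromatic nitrogen. Among these compounds, this is the first measured step at this position that changes one place alone, as the earlier compounds offered no such step. It shows that, in this pair, a four-membered non-aromatic ring with an oxygen can replace methyl on this nitrogen without a step beyond the scatter, and no evidence here bears on why the number holds.

The compounds shown leave open whether a piperidin-4-yl group, a carboxymethyl group or a longer chain such as n-butyl on this nitrogen would also stay within the scatter of methyl. They also leave open whether the oxetan-3-yl exchange would read the same with a chlorine in place of the neighbouring ring methyl group.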